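The source may hold more compounds than are shown below. What is called first, only, known or untested is meant among the compounds shown, and "the series" means these compounds.

Measured so far in a functional assay on DU-145 cells (Homo sapiens) for inhibition, read by trypan blue exclusion, with a stated time of 96 h (on this read-out higher numbers stand for weaker inhibition of growth and lower numbers for stronger inhibition of growth), on the shared core:
- compound 1 (`Cc1ccc(S(=O)(=O)/C(=C/c2ccc(C)s2)C(=O)c2ccc(Br)cc2)cc1`) gives 25000 nM
- compound 2 (`Cc1ccc(S(=O)(=O)/C(=C/c2c(O)cc(O)cc2O)C(=O)c2ccc(Br)cc2)cc1`) gives > 100000 nM as a limit of the assay, not a number
- compound 3 (`COc1ccc(S(=O)(=O)/C(=C/c2ccc(Br)cc2)C(=O)c2ccc(Br)cc2)cc1`) gives 6000 nM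

Compound 3 stands lowest of the two true numbers, with 6000 nM in this assay. The nearest is compound 1, whose 25000 nM is a higher number, beyond the scatter.

Next is compound 4 (`Cc1ccc(S(=O)(=O)/C(=C/c2ccc(Br)cc2)C(=O)c2ccc(Br)cc2)cc1`), which has methyl in place of methoxy on an aromatic carbon, para to a large group (methyl in place of methoxy on an aromatic carbon), so 4-methoxyphenyl becomes 4-methylphenyl.

Among the compounds with values here, the one measured step (an at least 4.0-fold higher number from compound 1 to compound 2 (0.60 log units; beyond the scatter)) lies at another place on the shared core. Within the data shown here, no measured step covers methoxy and methyl, so it sets no size for this change. Without such a measurement, no shift in either direction beyond the scatter is expected.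

The expected step (a 1.2-fold higher number from compound 3 to compound 4 (0.07 log units; within the scatter)) is estimated to stay within the scatter. For compound 4 the estimate is 7000 nM in this assay, with an expected range from 2000 nM to 25000 nM on this read-out.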

Compound 4, concentration for 50% growth inhibition: 10000 nM
Estimate against measurement, compound 4: 1.4-fold (0.15 log units) below, within the range that was stated.
By their numbers in this assay, from the lowest: compounds 3 and 4 (each within the scatter of the next); then compound 1. At a limit, above all of these: compound 2.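

In this assay, exchanging 4-methoxyphenyl for 4-methylphenyl gives a 1.7-fold higher number from compound 3 to compound 4 (0.22 log units; within the scatter), so on this aromatic carbon, para to a large group, the two groups are not told apart by this read-out. Within the data shown here, compound 4 also allows the first single-place reading of the group on the double-bonded chain carbon, where 4-bromophenyl in place of 5-methylthiophen-2-yl gives a 2.5-fold lower number from compound 1 to compound 4 (0.40 log units; beyond the scatter). At that same place, 4-bromophenyl in place of 2,4,6-trihydroxyphenyl gives an at least 10-fold lower number from compound 2 to compound 4 (1.00 log units; beyond the scatter), a step that rests on a limit of the assay for compound 2, not a number: the limit of > 100000 nM in this assay, at which 1 of the 4 values shown sits.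

As far as these compounds go, how an amine, a carboxylic acid or a longer chain such as butoxy would read in place of methoxy on this aromatic carbon stays open. Also open, from the compounds shown here alone, is whether phenyl without a substituent or 4-chlorophenyl would read like 4-bromophenyl on the double-bonded chain carbon.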